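Swapping the aryl group on the amine nitrogen

The source may hold more compounds than are shown below. What is called first, only, known or untested is meant among the compounds shown, and "the series" means these compounds.

Compound 3 `CN1C(=O)/C(=C(/S)N(C)c2ccc(F)cc2)C(=O)c2cc(Cl)ccc21` was tested in a functional assay on the whole organism for inhibition, with Mus musculus as the target, at a dose of 10 mg/kg by the oral route (a lower number here means less inhibition, a higher number more inhibition at the dose given (going by the name of the read-out)), where compound 3 gives 54%. Of the three numbers measured, that is the second highest. Compound 1 `CN1C(=O)/C(=C(/S)N(C)c2ccccc2)C(=O)c2cc(Br)ccc21` gives 56% in this assay, and the two values lie within the scatter of each other. Going by the values given here, compound 2 `CN1C(=O)/C(=C(/S)N(C)c2ccc(OC(F)(F)F)cc2)C(=O)c2cc(Cl)ccc21` gives 39%, and the step of a number 15 percentage points higher from compound 2 to compound 3 (beyond the scatter) is the only change measured so far; it alters the group attached to the amine nitrogen and lies beyond the scatter.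

Compound 4 `CN1C(=O)/C(=C(/S)N(C)c2cccc(Cl)c2)C(=O)c2cc(Cl)ccc21` differs from compound 3 at the same place: 3-chlorophenyl in place of 4-fluorophenyl on an amine nitrogen. Among the compounds with values here, the one measured step touches the same position but exchanges a different pair of groups, so it gives only a loose guide. Within the data shown here, no measured pair shows what a 3-chlorophenyl does here. The expectation is therefore a step of a number 4 percentage points lower from compound 3 to compound 4 (within the scatter) that stays within the scatter, with no clear direction. Compound 4 is estimated to give 50% in this assay, within a range from 35% to 65%.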

Compound 4, a percentage reported as inhibition, in the whole organism at one dose (the size of the read-out at that dose, not a potency): 63%
Beside the measured number, compound 4's estimate is 13 percentage points below it; the range from low to high includes it.
By their numbers in this assay, from the lowest: compound 2; then compounds 3, 1 and 4 (each within the scatter of the next).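

The step of a number 9 percentage points higher from compound 3 to compound 4 (within the scatter) shows that in this assay this place on the amine nitrogen accepts a 3-chlorophenyl as readily as a 4-fluorophenyl. This exchange alters both the halogen and where it sits on the ring, yet the result stays within the scatter, so the two changes cannot be told apart here. Among the chloro compounds, the only clear separation so far remains the one involving the 4-trifluoromethoxyphenyl group of compound 2, and no measurement on hand offers an explanation for any of this.

Still open, from the compounds shown here alone, is whether a 4-chlorophenyl or a 3-fluorophenyl would give a number that can be separated from these. Also open, going by these compounds, is whether the aromatic ring is needed at all, or whether a cyclohexyl group or a pyridyl ring could take its place.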